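This account rests on a few compounds, and the source may have more. Where it says the series, first, only, none or still open, it means among the compounds named here.

Measured compounds in a functional assay on Hep 3B2 cells (Homo sapiens) for antiproliferative activity, read by MTT assay, with a stated time of 24 h, tested at 0.14 ug/mL; a higher number here means a stronger effect of the compound at the concentration tested, a lower number a weaker effect:
compound 1 `Cc1ccc2nc(C(=O)Nc3c(F)cc(-c4cccc(F)c4)cc3F)c(C)c(O)c2c1`: 2.34%
compound 2 `Cc1c(C(=O)Nc2c(F)cc(-c3cccc(F)c3)cc2F)nc2ccc(F)cc2c1O`: 2.65%
compound 3 `CCOc1ccc2nc(C(=O)Nc3c(F)cc(-c4cccc(F)c4)cc3F)c(C)c(O)c2c1`: 0.01%

All three numbers lie close together. Among the measured compounds shown here, compound 3 gives the smallest of them, but the steps of a number 2.3 percentage points lower from compound 1 to compound 3 (within the scatter) and a number 2.6 percentage points lower from compound 2 to compound 3 (within the scatter) are both within the scatter, as is a number 0.3 percentage points higher from compound 1 to compound 2 (within the scatter), so no compound stands apart on this assay.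

Compound 4 `Cc1c(C(=O)Nc2c(F)cc(-c3cccc(F)c3)cc2F)nc2ccc(OC(F)(F)F)cc2c1O` differs from compound 3 by trifluoromethyl in place of ethyl on an oxygen on an aromatic ring. For the measured compounds named here, no measured step touches that oxygen; the nearest comparisons are the exchanges at the same aromatic carbon, a number 2.3 percentage points lower from compound 1 to compound 3 (within the scatter) and a number 2.6 percentage points lower from compound 2 to compound 3 (within the scatter), both within the scatter. On that basis compound 4 is expected to show no step beyond the scatter, a number 1.5 percentage points higher from compound 3 to compound 4 (within the scatter). The estimate for compound 4 in this assay is 1.5%, with a range of 0% to 9%.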

Compound 4, a percentage reported as inhibition, at one concentration (the size of the read-out at that concentration, not a potency): 2.01%
Compound 4: middle estimate off by 0.5 percentage points, on the low side; the measured number falls inside the stated range.
By their numbers in this assay, from the lowest: compounds 3, 4, 1 and 2 (each within the scatter of the next).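

In this assay the oxygen itself is now varied, and trifluoromethyl in place of ethyl stays within the scatter (a number 2 percentage points higher from compound 3 to compound 4 (within the scatter)). At the aromatic carbon, trifluoromethoxy does not separate from fluoro (a number 0.6 percentage points lower from compound 2 to compound 4 (within the scatter)) or methyl (a number 0.3 percentage points lower from compound 1 to compound 4 (within the scatter)), so all four groups there remain indistinguishable. No supporting data bear on this result.

Still open, from the compounds shown here alone, is whether an amine or a carboxylic acid at this aromatic carbon, or a longer chain on the oxygen, would move the read-out beyond the scatter. Going by these compounds, these results also describe only the size of the effect at the single tested concentration, and whether the effect would be stronger or weaker at any other concentration remains unknown.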